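The source may hold more compounds than are shown below. What is called first, only, known or untested is meant among the compounds shown, and "the series" means these compounds.

Working notes on the series. Two compounds have been run in an ADME assay on 184B5 cells (Homo sapiens) for cytotoxicity, read by sulforhodamine B assay, with a stated time of 48 h; a higher number here means a weaker inhibitor of growth, a lower number a stronger inhibitor of growth. Compound 1, `O=C1C(=O)N(CN(c2ccccc2)c2ccccc2)c2cccc(Br)c21`, gives 98500 nM in this assay. Compound 2, `CN(C)CN1C(=O)C(=O)c2ccccc21`, carries a different substituent on the ring nitrogen of the core and no halogen on the fused aromatic ring; in this assay compound 2 gives 73700 nM. The two numbers lie within the scatter of each other, so compound 1 cannot be separated from compound 2 on the evidence so far, and both sit at the weak end of growth inhibition.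

The next compound, compound 3, `O=C1C(=O)N(CN(c2ccccc2)c2ccccc2)c2cccc(Cl)c21`, has not yet been measured in this assay. It differs from compound 1 in one place: chloro in place of bromo on an aromatic carbon. Within the data shown here, no measured pair shows what this exchange does in this assay, so there is no step to lean on. With the halogen kept at the same place on the core and only its identity exchanged, no change beyond the scatter is expected in either direction; the step from compound 1 to compound 3 is estimated at a 1.0-fold higher number from compound 1 to compound 3 (0.01 log units; within the scatter). For compound 3 the expected value in this assay is 100000 nM, with a range from 40000 nM to 250000 nM.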

Compound 3, concentration for 50% growth inhibition: 96800 nM
Beside the measured number, compound 3's estimate is 1.0-fold (0.01 log units) above it; low and high end bracket the measured number.
By their numbers in this assay, from the lowest: compounds 2, 3 and 1 (each within the scatter of the next).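

Among these compounds, this is the only pair that differs at a single place, so it gives the first direct reading at this position. In this assay, chloro in place of bromo on an aromatic carbon of the six-membered aromatic ring of carbon only, ortho to a fused ring and meta to a fused ring, gives a 1.0-fold lower number from compound 1 to compound 3 (0.01 log units; within the scatter) and leaves the two halogens indistinguishable at this position while the rest of compound 1 stays the same. No measurement at hand offers an explanation for this result, and the pair shows only that the identity of these two halogens does not separate the compounds in this assay.

The compounds shown leave open whether a halogen at this position matters at all, since the series holds no partner with hydrogen on this aromatic carbon and the same substituent on the ring nitrogen. Also open, from the compounds shown here alone, is whether fluoro, a methoxy group, an amine or a carboxylic acid at this same place would read apart from bromo and chloro, and whether any such group would move the series away from the weak end of growth inhibition.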